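The source may report more compounds than this note shows. Statements on the series, on what has been measured and on what is new or still open speak of the compounds shown alone.

Measured so far in an assay on isolated protein for inhibition of tyrosine-protein kinase receptor UFO (Homo sapiens), read by FRET and Z'-LYTE, with a stated time of 1.5 h; a lower number here means a stronger inhibitor, a higher number a weaker inhibitor:
compound 1 `Cc1ccc2c(c1)c(=O)c(C(=O)Nc1ccc(Oc3ncnc4[nH]cc(-c5ccccc5)c34)c(F)c1)c(C)n2C` — 100 nM
compound 2 `CCc1c(C(=O)Nc2ccc(Oc3ncnc4[nH]cc(-c5ccccc5)c34)c(F)c2)c(=O)c2cc(C)ccc2n1C` — 78 nM
compound 3 `Cc1ccc2c(c1)c(=O)c(C(=O)Nc1ccc(Oc3ncnc4[nH]cc(-c5ccccc5)c34)c(F)c1)c(-c1ccccc1)n2C` — 78 nM

Compound 1 carries the highest of the three numbers, yet both others sit within the scatter of it: a 1.3-fold lower number from compound 1 to compound 2 (0.11 log units; within the scatter) and a 1.3-fold lower number from compound 1 to compound 3 (0.11 log units; within the scatter). Between compound 2 and compound 3 there is no change at the digits printed from compound 2 to compound 3 (within the scatter).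

Compound 4 `CCCc1ccc2c(c1)c(=O)c(C(=O)Nc1ccc(Oc3ncnc4[nH]cc(-c5ccccc5)c34)c(F)c1)c(C)n2C` is still to be measured. It differs from compound 1 by ethyl in place of hydrogen on a saturated chain carbon bound to an aromatic carbon; cut one bond further out, the same difference reads methyl to propyl. The nearest measured precedent is the step from compound 1 to compound 2, also a hydrogen replaced by an alkyl on a saturated chain carbon bound to an aromatic carbon, which gave a 1.3-fold lower number from compound 1 to compound 2 (0.11 log units; within the scatter). The steps to compound 3 swap alkyl for phenyl on an aromatic carbon and bear less directly; they too stayed within the scatter. Lengthening a chain here is therefore expected to give no step beyond the scatter in this assay, in either direction. The expected value of compound 4 is 90 nM, with range 40 nM to 200 nM. That expectation means a 1.1-fold lower number from compound 1 to compound 4 (0.05 log units; within the scatter).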

Compound 4, half-maximal inhibitory concentration: 61 nM
Compound 4: the middle estimate sits 1.5-fold (0.17 log units) above what was measured; the measured number falls inside the stated range.
By their numbers in this assay, from the lowest: compounds 4, 2, 3 and 1 (each within the scatter of the next).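

In this assay, the step at this position gives a 1.6-fold lower number from compound 1 to compound 4 (0.21 log units; within the scatter), with ethyl in place of hydrogen on a saturated chain carbon bound to an aromatic carbon. For the compounds shown here, the earlier steps changed a different alkyl group of the shared core, so this is the first reading at this position, and it shows that methyl to propyl, with 2 more heavy atoms and no ring, stays within the scatter. No measured evidence on hand accounts for this result.

From the compounds shown here alone, it remains open whether a longer chain such as butyl or pentyl, or a branched group such as isopropyl, would also stay within the scatter here. Going by these compounds, it is equally open how a phenyl, an amine or a carboxylic acid would read at this position in this assay, since the phenyl step lies elsewhere on the core.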